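A 2-Methylphenyl Urea Joins Three Measured Analogues

The compounds below may be only part of what the source reports. "The series", "measured", "known", "first", "only" and "open" are said of these compounds alone.

Three ureas built on one shared core have been tested in a functional assay on the whole organism (strain albino) with Mus musculus as the target, at a dose of 100 mg/kg by the intraperitoneal route; on this read-out higher numbers stand for more inhibition at the one dose given (going by the name of the read-out) and lower numbers for less inhibition. Compound 1 `COc1ccc(NC(=O)Nn2c(-c3ccccc3)nc3ccccc3c2=O)cc1` gives 52%. Compound 2 `O=C(Nc1ccccc1)Nn1c(-c2ccccc2)nc2ccccc2c1=O` gives 56%, and compound 3 `CCOc1ccc(NC(=O)Nn2c(-c3ccccc3)nc3ccccc3c2=O)cc1` gives 53%. On these numbers compound 3 sits close to both companions: the step of a number 1 percentage points higher from compound 1 to compound 3 (within the scatter) and the step of a number 3 percentage points lower from compound 2 to compound 3 (within the scatter) are each small, so the three values cannot be told apart and none of them can be said to give the highest or lowest number.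

Compound 4 `Cc1ccccc1NC(=O)Nn1c(-c2ccccc2)nc2ccccc2c1=O` has not yet been measured. Against compound 3 the change is 2-methylphenyl in place of 4-ethoxyphenyl on an amide-type nitrogen. Going by the values given here, two measured steps bear on it, both touching the aromatic ring that is exchanged: the step of a number 3 percentage points lower from compound 2 to compound 3 (within the scatter) shows what an ethoxy group adds over hydrogen, and the step of a number 4 percentage points higher from compound 1 to compound 2 (within the scatter) shows what a methoxy group adds; both lie within the scatter. Among the compounds with values here, no measured step involves a methyl group on that ring, so the expectation rests on the alkoxy groups having made no difference that could be seen. For compound 4 the step of a number 1 percentage points higher from compound 3 to compound 4 (within the scatter) is therefore expected to stay within the scatter. Compound 4 is estimated to give 54% in this assay, with a range from 42% to 66%.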

Compound 4, a percentage reported as inhibition, in the whole organism at one dose (the size of the read-out at that dose, not a potency): 59%
Beside the measured number, compound 4's estimate is 5 percentage points below it; measured number inside the range.
By their numbers in this assay, from the lowest: compounds 1, 3, 2 and 4 (each within the scatter of the next).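

Going by these compounds alone, compound 4 is the first in this set whose ring at the amide-type nitrogen carries no oxygen, and in this assay that exchange gives a number 6 percentage points higher from compound 3 to compound 4 (within the scatter) and a number 7 percentage points higher from compound 1 to compound 4 (within the scatter), so leaving the 4-ethoxyphenyl or the 4-methoxyphenyl for the 2-methylphenyl produces no difference that can be told from the usual variation. Within the data shown here, it also gives the first reading for an alkyl group on that ring, with a number 3 percentage points higher from compound 2 to compound 4 (within the scatter), so a methyl group joins the two alkoxy groups as a substituent whose effect cannot be distinguished from that of hydrogen at this one dose, and all four compounds remain unresolved from one another. No evidence is available that would account for these numbers.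

The compounds shown leave open whether any substituent on this ring can move the read-out beyond the scatter, for instance an amine, a carboxylic acid or a longer alkoxy chain. Among these compounds, they also leave open whether a methyl group gives the same number in another place on the ring, since the only methyl compound here is the 2-methylphenyl urea.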